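Adding one methyl to the most rapidly cleared compound

This account rests on a few compounds, and the source may have more. Where it says the series, first, only, none or still open, it means among the compounds named here.

compound 1 `Cc1ccc([C@H](C(=O)N(C)C)N2C(=O)[C@@H](C3Cc4ccccc4C3)NC(=O)[C@H]2CC(C)C)cn1` gives 3000 mL.min-1.g-1
compound 2 `CC[C@H](C)[C@@H]1C(=O)N[C@H](C2Cc3ccccc3C2)C(=O)N1[C@@H](C(=O)N(C)C)c1ccc(C)[n+]([O-])c1` gives 1 mL.min-1.g-1
compound 3 `CC[C@H](C)[C@@H]1C(=O)N[C@H](C2Cc3ccccc3C2)C(=O)N1[C@@H](C(=O)N(C)C)c1cnc(C)cc1C` gives 1 mL.min-1.g-1

In an in vitro ADME assay on microsomes from liver (Rattus norvegicus) for metabolic stability (a lower number here means slower removal, a higher number faster removal of the compound), compound 1 stands highest of the three, and compound 2 and compound 3 both lie far lower, beyond the usual scatter. Compound 4 `Cc1ccc([C@H](C(=O)N(C)C)N2C(=O)[C@@H](C3Cc4ccccc4C3)NC(=O)[C@H]2CC(C)(C)C)cn1` has not been measured yet. It differs from compound 1 in one place: methyl in place of hydrogen on a saturated chain carbon bound to three saturated chain carbons with, in words, methyl in place of hydrogen on a saturated chain carbon bound to three saturated chain carbons, which turns isobutyl into neopentyl.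

Among the compounds with values here, the only measured step between two compounds that differ in one place is no change at the digits printed from compound 2 to compound 3 (within the scatter) and it concerns the aromatic ring group, not this chain, so it offers little guidance. Within the data shown here, no measured pair isolates a change in the chain itself. Compound 1 at 3000 mL.min-1.g-1 is therefore the starting point. Yet compound 3 at 1 mL.min-1.g-1 shows how far a related compound can sit from it, so the range must be wide and reach mainly downward. The expected step in this assay is a 1.5-fold lower number from compound 1 to compound 4 (0.18 log units; within the scatter) and so no change beyond the scatter is expected. The expected value for compound 4 is 2000 mL.min-1.g-1 with 50 mL.min-1.g-1 as the estimated lower end and 6000 mL.min-1.g-1 as the upper end of the range.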

Compound 4, intrinsic clearance in microsomes: 3 mL.min-1.g-1
Beside the measured number, compound 4's estimate is 670-fold (2.82 log units) above it, outside the stated range (below it).
By their numbers in this assay, from the lowest: compounds 2 and 3 (each within the scatter of the next); then compound 4; then compound 1.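

In this assay, the chain of compound 1 proves to be a place where a very small change can matter a great deal: turning isobutyl into neopentyl, with methyl in place of hydrogen on a saturated chain carbon bound to three saturated chain carbons, gives a 1000-fold lower number from compound 1 to compound 4 (3.00 log units; beyond the scatter) with the rest of the structure unchanged. Within the data shown here, the earlier compounds could not show this, as compound 2 and compound 3 each differ from compound 1 in more than one place, and the only step between them concerns the aromatic ring group and not this chain. What lies behind a step of this size cannot be told from the information available here.

This is a single pair, so the compounds shown leave open whether the added methyl would have a similar effect in a compound with a different aromatic ring group, such as the one in compound 3. They also leave open how the number would respond to other groups on this chain, such as a hydroxyl, an amine or a longer chain.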